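Furan amide series: swapping a fluorinated phenyl for methylpyridinyl

A few compounds are considered here, and "the series" means these few. Any claim that something is new, unique, unknown or untested is made for them only; others in the source may bear on it.

Compound 1 `Cc1ccc(F)cc1N(C)C(=O)c1ccc(-c2ccc(O)cc2)o1` gives 12 nM in an assay on T47D cells for inhibition of 17-beta-hydroxysteroid dehydrogenase type 1 (Homo sapiens), read by HPLC, with a stated time of 24 h; on this read-out lower numbers stand for stronger inhibition and higher numbers for weaker inhibition. Within the data shown here, compound 2 `Cc1c(F)cccc1N(C)C(=O)c1ccc(-c2ccc(O)cc2)o1` gives 50 nM, the higher of the two numbers, and the only measured step, a 4.2-fold higher number from compound 1 to compound 2 (0.62 log units; beyond the scatter), separates them. Compound 3 `Cc1cccnc1N(C)C(=O)c1ccc(-c2ccc(O)cc2)o1` differs from compound 2 by 3-methylpyridin-2-yl in place of 3-fluoro-2-methylphenyl on an amide-type nitrogen. Among the measured compounds shown here, no measured step touches a nitrogen-containing ring on this nitrogen, so the only guidance is that the one ring change seen gave a modest step. For compound 3 the number is therefore expected to stay within the scatter of compound 2, so that a 1.2-fold higher number from compound 2 to compound 3 (0.08 log units; within the scatter) is the estimated step, giving 60 nM with a range of 15 nM to 250 nM.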

Compound 3, half-maximal inhibitory concentration: 1100 nM
For compound 3 the middle estimate is 18-fold (1.26 log units) below the measured one, outside the stated range (above it).
By their numbers in this assay, from the lowest: compound 1; then compound 2; then compound 3.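

The ring on the amide-type nitrogen matters far more here than the place of its fluorine: in this assay, 3-methylpyridin-2-yl in place of 3-fluoro-2-methylphenyl brings a 22-fold higher number from compound 2 to compound 3 (1.34 log units; beyond the scatter), and in place of 5-fluoro-2-methylphenyl it brings a 92-fold higher number from compound 1 to compound 3 (1.96 log units; beyond the scatter). Both steps are large, whereas moving the fluorine gave only a modest one. No supporting measurement bears on why this change weighs so heavily.

The ring nitrogen arrives as the fluorine leaves, so the compounds shown cannot tell these two changes apart. A plain 2-methylphenyl on this nitrogen, or a fluorinated methylpyridinyl ring, would separate them.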